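This account rests on a few compounds, and the source may have more. Where it says the series, first, only, none or still open, it means among the compounds named here.

Compound 1 `C=C1C(=O)O[C@H]2CC3=C[C@H](C/C(C)=C/[C@@H](OC(=O)/C=C/c4ccccc4)[C@H]12)OC3=O` carries a 2-phenylethenyl group on the carbonyl carbon of its ester. In a functional assay on NCI-H460 cells (Homo sapiens) for cytotoxicity, read by MTT assay, with a stated time of 48 h (a lower number here means a stronger inhibitor, a higher number a weaker inhibitor), compound 1 gives > 10000 nM, which is a limit of the assay and not a number. Two measured compounds share its core and differ from it only at that carbonyl carbon. Compound 2 `C=C1C(=O)O[C@H]2CC3=C[C@H](C/C(C)=C/[C@@H](OC(=O)C45CCC(C)(C(=O)O4)C5(C)C)[C@H]12)OC3=O` gives 2000 nM in this assay. Compound 3 `C=C1C(=O)O[C@H]2CC3=C[C@H](C/C(C)=C/[C@@H](OC(=O)C4CC4)[C@H]12)OC3=O` gives 3000 nM in this assay. Both replacements of the 2-phenylethenyl group move the number the same way: the step of an at least 5.0-fold lower number from compound 1 to compound 2 (0.69 log units; beyond the scatter) and the step of an at least 3.3-fold lower number from compound 1 to compound 3 (0.52 log units; beyond the scatter) each run downward, and their sizes are known only as floors because of the limit of > 10000 nM in this assay, at which 1 of the 3 values shown sits. Between the two replacements themselves the step of a 1.5-fold higher number from compound 2 to compound 3 (0.18 log units; within the scatter) shows no difference to speak of.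

Compound 4 `C=C1C(=O)O[C@H]2CC3=C[C@H](C/C(C)=C/[C@@H](OC(=O)C(C)(C)CC)[C@H]12)OC3=O` has not yet been measured. It differs from compound 1 in one place: 1,1-dimethylpropyl in place of 2-phenylethenyl on a carbonyl carbon. The two measured steps that bear on it both leave the same 2-phenylethenyl group and both lower the number by at least a modest amount, so a drop of similar size is expected here too. Compound 4 is therefore estimated to give 3000 nM in this assay, with a range from 1000 nM to 10000 nM. That estimate would mean the step of an at least 3.3-fold lower number from compound 1 to compound 4 (0.52 log units; beyond the scatter).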

Compound 4, half-maximal inhibitory concentration: 6100 nM
For compound 4 the middle estimate is 2.0-fold (0.31 log units) below the measured one; the measured number falls inside the stated range.
By their numbers in this assay, from the lowest: compounds 2 and 3 (each within the scatter of the next); then compound 4. At a limit, above all of these: compound 1.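

Compound 4 shows that the carbonyl carbon of this ester does not treat all replacements of 2-phenylethenyl alike, a difference that compounds 2 and 3 alone did not reveal: in this assay the 1,1-dimethylpropyl group gives a 2.0-fold higher number from compound 3 to compound 4 (0.31 log units; beyond the scatter) and a 3.1-fold higher number from compound 2 to compound 4 (0.48 log units; beyond the scatter). Among these three compounds, the two groups that carry a ring give lower numbers than the 1,1-dimethylpropyl group, which has none, but compound 1 goes against any simple link between a ring and a lower number, since its 2-phenylethenyl group also carries one. The gain on leaving 2-phenylethenyl is also less secure here, with the step of an at least 1.6-fold lower number from compound 1 to compound 4 (0.21 log units; that floor lies within the scatter) known only as a floor, because the value of compound 1 is a limit and not a number: the limit of > 10000 nM in this assay, at which 1 of the 4 values shown sits.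

The compounds shown leave open how far compound 1 really lies from the others, and whether its ring or its double bond matters more, which a phenyl group or a saturated 2-phenylethyl chain on the same carbonyl carbon could help separate. They also leave open how an amine, a carboxylic acid or a longer carbon chain would read at this position.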